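Shortening the Chain to the Thiazolium Head Group

The source may report more compounds than this note shows. Statements on the series, on what has been measured and on what is new or still open speak of the compounds shown alone.

Compound 1 `CCCCCCCCCCCCCCCCCC1OCC(COCCCCCC[N+](C)(C)C)O1` was tested in a functional assay on artery with platelet-activating factor receptor (Rattus norvegicus) as the target (on this read-out lower numbers stand for an effect already at smaller amounts and higher numbers for an effect only at larger amounts of compound), and reached no number there; its reading of > 5 mg/kg is only a limit of the assay. Compound 2 `CCCCCCCCCCCCCCCCCCOCC1CC(COCCCCCCC[n+]2ccsc2)CO1` gives 2.1 mg/kg in this assay, and this is the only actual number shown. The other reading in this assay is the limit of > 5 mg/kg in this assay, at which 1 of the 2 values shown sits, so compound 2 cannot be ranked against anything measured. Compound 3 `CCCCCCCCCCCCCCCCCCOCC1CC(COCCCCC[n+]2ccsc2)CO1` differs from compound 2 in a single place: a group of 5 heavy atoms (3 carbon, 1 nitrogen, 1 sulfur; one five-membered aromatic ring with 2 hetero atoms) in place of a group of 7 heavy atoms (5 carbon, 1 nitrogen, 1 sulfur; one five-membered aromatic ring with 2 hetero atoms), on a saturated chain carbon, five bonds along the chain from an oxygen on a saturated carbon. Among the measured compounds shown here, no measured pair shows the effect of such a change, so the step has to be guessed. The step from compound 2 to compound 3 is expected to be a 1.3-fold higher number from compound 2 to compound 3 (0.12 log units; within the scatter), a shift that would not exceed the usual scatter of this assay. Compound 3 is therefore estimated to give about 2.8 mg/kg, with a likely range from 1.1 mg/kg to 7 mg/kg.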

Compound 3, dose for 50% inhibition: 2.5 mg/kg
The estimate for compound 3 lay 1.1-fold (0.05 log units) above the measured number; the measured number falls inside the stated range.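

Among the compounds shown here, the first measured pair that differs in one place shows that, in this assay, putting the group of 5 heavy atoms in place of the group of 7 heavy atoms gives a 1.2-fold higher number from compound 2 to compound 3 (0.08 log units; within the scatter). At this place, on a saturated chain carbon, five bonds along the chain from an oxygen on a saturated carbon, this change therefore leaves compound 2 and compound 3 indistinguishable, and the activity seen for compound 2 does not depend on the larger group. Nothing shown here explains why the two groups read alike.

This single pair does not show how far the position tolerates change, since a much longer chain could still behave differently. It also leaves open what would happen if an amine or a carboxylic acid replaced the five-membered aromatic ring.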